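This account rests on a few compounds, and the source may have more. Where it says the series, first, only, none or still open, it means among the compounds named here.

Compound 1 `COc1ccccc1N1CCN(CCCNC(=O)NN(Cc2ccc(-c3ccccc3)cc2)c2ccc(F)cc2)CC1`: 5.9 nM
Compound 2 `O=C(NCCCN1CCN(c2ccc(Cl)cc2)CC1)NN(Cc1ccccc1)c1ccccc1`: 9.7 nM
Compound 3 `O=C(NCCCN1CCN(c2ccc(Br)cc2)CC1)NN(Cc1ccccc1)c1ccccc1`: 14 nM

All three were measured in an assay on CHO cells for displacement of a labelled ligand from D(4) dopamine receptor (Homo sapiens), read by radioligand binding; a lower number here means a stronger inhibitor, a higher number a weaker inhibitor. Compound 3 gives the highest of the three numbers; compound 2 lies nearest, within the scatter, while compound 1 lies furthest, beyond it. Compound 4 `O=C(NCCCN1CCN(c2ncccn2)CC1)NN(Cc1ccccc1)c1ccccc1` differs from compound 3 in one place: pyrimidin-2-yl in place of 4-bromophenyl on an amine nitrogen in a ring. Among the measured compounds shown here, the only measured step, a 1.4-fold higher number from compound 2 to compound 3 (0.16 log units; within the scatter), exchanges one halogen for another and so does not bear on replacing the whole ring; no measured pair shows what a pyrimidin-2-yl on an amine nitrogen in a ring does here. A modest step is therefore expected, a 1.8-fold higher number from compound 3 to compound 4 (0.25 log units; within the scatter), toward a higher number, with wide uncertainty. Compound 4 is estimated at 25 nM, with a range from 8 nM to 80 nM.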

Compound 4, inhibition constant: 18 nM
Compound 4: middle estimate off by 1.4-fold (0.14 log units), on the high side, and the stated range covers the measured number.
By their numbers in this assay, from the lowest: compounds 1, 2, 3 and 4 (each within the scatter of the next, the first and the last beyond it).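

Pyrimidin-2-yl on the amine nitrogen in a ring takes the place of 4-bromophenyl (a 1.3-fold higher number from compound 3 to compound 4 (0.11 log units; within the scatter)) and of 4-chlorophenyl (a 1.9-fold higher number from compound 2 to compound 4 (0.27 log units; within the scatter)) without a step beyond the scatter. The earlier halogen exchange left the carbon-only ring in place, whereas these steps show that this position also accepts an aromatic ring with hetero atoms and hydrogen-bond acceptors. No measurement at hand gives a reason for this.

Going by these compounds, whether a saturated group such as cyclohexyl or a small methyl on this nitrogen would fit as well remains open. So does whether pyrimidin-2-yl would behave alike on the core of compound 1.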